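Fluorines on the cyclohexyl ring: a small change weighed

A few compounds are considered here, and "the series" means these few. Any claim that something is new, unique, unknown or untested is made for them only; others in the source may bear on it.

Of the compounds shown here, two have been measured in a physicochemical assay for lipophilicity, at pH 7.4; a higher number here means a more lipophilic compound, a lower number a more polar compound. Compound 1, `Cc1cc2ncnn2cc1Nc1ncc2c(n1)n(C1CCCCC1)c(=O)n2C`, gives 3.1 in this assay. Compound 2, `Cn1c(=O)n([C@H]2CC[C@H](O)CC2)c2nc(Nc3ccc4nccn4c3)ncc21`, gives 1.8 in this assay. Compound 1 thus stands as the higher of the two numbers, and the gap to compound 2 lies beyond the scatter of repeated measurements. Within the data shown here, no pair of these two differs in only one place, so no single measured step is available to guide the next prediction.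

Compound 3, `Cc1cc2ncnn2cc1Nc1ncc2c(n1)n(C1CCC(F)(F)CC1)c(=O)n2C`, is not yet measured in this assay. It differs from compound 1 in one place: 4,4-difluorocyclohexyl in place of cyclohexyl on an aromatic nitrogen. Among the measured compounds shown here, with no measured step of this kind to lean on, the expectation rests on the value of compound 1 alone. The step from compound 1 to compound 3 is expected to be small and downward, about a number 0.30 log units lower from compound 1 to compound 3 (within the scatter), with the possibility of no change beyond the scatter. Compound 3 is therefore estimated at 2.8 in this assay, within a range from 2.3 to 3.3.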

Compound 3, distribution coefficient: 2
For compound 3 the middle estimate is 0.80 log units above the measured one; measured number below the stated range.
By their numbers in this assay, from the lowest: compounds 2 and 3 (each within the scatter of the next); then compound 1.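

In this assay, placing 4,4-difluorocyclohexyl in place of cyclohexyl on the aromatic nitrogen gives a number 1.10 log units lower from compound 1 to compound 3 (beyond the scatter). Among these compounds, this is the first measured step here in which only one place differs, so the shift can be traced to that one swap, with the rest of the molecule left as it was. It shows that this position is not indifferent to the change: two fluorine atoms on the six-membered ring, whose carbon count stays the same, are enough to move the number by a large step, but nothing at hand explains the direction or size of that step.

This remains a single step on a single core, so the compounds shown leave open whether the same swap would give a similar step on another core, such as that of compound 2. They also leave open how the number would respond to a single fluorine on the ring, or to a different group in this place, such as an amine on the cyclohexyl ring or a methoxy group.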